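Tetrazole for Triazole on the Shared Core

The source may report more compounds than this note shows. Statements on the series, on what has been measured and on what is new or still open speak of the compounds shown alone.

Measured compounds in an assay on CHO cells for displacement of a labelled ligand from prostaglandin E2 receptor EP3 subtype (Homo sapiens), read by radioligand binding; on this read-out higher numbers stand for weaker inhibition and lower numbers for stronger inhibition:
compound 1 `CCn1ncc2c(F)cc(-c3ccc(C(CC)(CC)c4nnc[nH]4)c(=O)[nH]3)cc21`, giving 17 nM
compound 2 `CC(C)C(Cc1nnc[nH]1)c1ccc(-c2ccc3cccc(F)c3c2)[nH]c1=O`, giving 10 nM
compound 3 `CCn1ncc2c(F)cc(-c3ccc(C(CC)(CC)c4nncn4C)c(=O)[nH]3)cc21`, giving 54 nM

Compound 2 has the lowest of the three numbers; compound 1 lies within the scatter of it, while compound 3 stands further off, beyond the scatter. Compound 4 `CC(C)C(Cc1nnn[nH]1)c1ccc(-c2ccc3cccc(F)c3c2)[nH]c1=O` differs from compound 2 in one place: 1H-tetrazol-5-yl in place of 4H-1,2,4-triazol-3-yl on a saturated chain carbon, two bonds along the chain from an aromatic carbon.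

Going by the values given here, only one measured step exists, and it is a different change: a 3.2-fold higher number from compound 1 to compound 3 (0.50 log units; beyond the scatter), a modest loss. Among the compounds with values here, it does not touch the ring swap of compound 2 to compound 4, so there is no direct precedent. The change keeps one hydrogen-bond donor and adds one acceptor within a five-membered aromatic ring of the same size, so compound 4 is expected to stay close to compound 2, with no step beyond the scatter in this assay.

Compound 4 is therefore estimated at 12 nM, with a range of 4 nM to 40 nM. This estimate means a step of a 1.2-fold higher number from compound 2 to compound 4 (0.08 log units; within the scatter), expected to lie within the scatter.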

Compound 4, inhibition constant: 34 nM
Beside the measured number, compound 4's estimate is 2.8-fold (0.45 log units) below it; measured number inside the range.
By their numbers in this assay, from the lowest: compounds 2, 1, 4 and 3 (each within the scatter of the next, the first and the last beyond it).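

In this assay, this saturated chain carbon proves sensitive to the identity of the ring it carries: 1H-tetrazol-5-yl in place of 4H-1,2,4-triazol-3-yl gives a 3.4-fold higher number from compound 2 to compound 4 (0.53 log units; beyond the scatter), a modest step but one beyond the scatter. The earlier compounds shown here showed only the effect of a methyl on an aromatic nitrogen, whereas here the ring keeps its five heavy atoms and its one hydrogen-bond donor, gaining a ring nitrogen and a hydrogen-bond acceptor, and the number still moves. No measurement given here accounts for this loss.

The compounds shown leave open whether the same exchange would produce a similar step on the core of compound 1. They also leave open how a carboxylic acid or a primary amide would compare with either ring at this position.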